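Bithiophene sulfonamide in place of the methylene-linked thiophene

The source may report more compounds than this note shows. Statements on the series, on what has been measured and on what is new or still open speak of the compounds shown alone.

Compound 1 `CCN(C/C=C/C#CC(C)(C)C)Cc1cccc(OCCN(C)S(=O)(=O)c2cccs2)c1` gives 60 nM in a functional assay on HepG2 cells for inhibition of squalene monooxygenase (Homo sapiens); a lower number here means a stronger inhibitor, a higher number a weaker inhibitor
Compound 2 `CCN(C/C=C/C#CC(C)(C)C)Cc1cccc(OCCN(C)S(=O)(=O)c2nccs2)c1` gives 170 nM in this assay
Compound 3 `CCN(C/C=C/C#CC(C)(C)C)Cc1cccc(OCCN(C)S(=O)(=O)Cc2cccs2)c1` gives 200 nM in this assay

Among the three measured compounds, compound 3 gives the highest number in this assay. Its nearest neighbour is compound 2, with a 1.2-fold higher number from compound 2 to compound 3 (0.07 log units; within the scatter), a gap within the scatter; compound 1 is furthest away, with a 3.3-fold higher number from compound 1 to compound 3 (0.52 log units; beyond the scatter). Compound 4 `CCN(C/C=C/C#CC(C)(C)C)Cc1cccc(OCCN(C)S(=O)(=O)c2cc(-c3ccsc3)cs2)c1` arises from compound 3 by 4-(thiophen-3-yl)thiophen-2-yl in place of (thiophen-2-yl)methyl on a sulfonyl sulfur. The step of a 3.3-fold higher number from compound 1 to compound 3 (0.52 log units; beyond the scatter) bears directly on this: it shows a higher number when the ring is attached through a methyl link, as in compound 3, rather than directly to the sulfonyl sulfur, as in compound 1. Compound 4 returns to direct attachment, so that step read in reverse points to a lower number. Within the data shown here, the added thiophen-3-yl ring has no measured counterpart, which widens the range. Compound 4 is therefore expected to give 70 nM, within 25 nM to 250 nM, a step of a 2.9-fold lower number from compound 3 to compound 4 (0.46 log units; beyond the scatter).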

Compound 4, half-maximal inhibitory concentration: 90 nM
Compound 4: the middle estimate sits 1.3-fold (0.11 log units) below what was measured; low and high end bracket the measured number.
By their numbers in this assay, from the lowest: compounds 1, 4, 2 and 3 (each within the scatter of the next, the first and the last beyond it).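

Adding thiophen-3-yl to the directly attached ring of compound 1 leaves the number in this assay within the scatter (a 1.5-fold higher number from compound 1 to compound 4 (0.18 log units; within the scatter)), so this position on the sulfonyl sulfur accepts a second ring. That two-ring group also gives a lower number than the methyl-linked ring (a 2.2-fold lower number from compound 3 to compound 4 (0.35 log units; beyond the scatter)), while its gap to the 1,3-thiazol-2-yl group stays within the scatter (a 1.9-fold lower number from compound 2 to compound 4 (0.28 log units; within the scatter)). Nothing available explains these results.

Open, on these data alone, is whether a phenyl ring or a morpholine in place of thiophen-3-yl would give a similar number.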